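Replacing the Hydroxy Group of Compound 3

The source may report more compounds than this note shows. Statements on the series, on what has been measured and on what is new or still open speak of the compounds shown alone.

In a functional assay on SW480 cells (Homo sapiens) for antiproliferative activity, read by MTT assay, with a stated time of 48 h (on this read-out lower numbers stand for stronger inhibition and higher numbers for weaker inhibition), compound 1 `CCCCCCC[C@H](CCO)n1cnc2c(Cl)ncnc21` gives 2930 nM, compound 2 `CCCCCCCC[C@H](CCO)n1cnc2c(Cl)ncnc21` gives 320 nM, and compound 3 `CCCCCCCCC[C@H](CCO)n1cnc2c(Cl)ncnc21` gives 1630 nM. Compound 3 therefore stands level with the highest number, as a 1.8-fold lower number from compound 1 to compound 3 (0.25 log units; within the scatter) shows, and clearly above the lowest, as a 5.1-fold higher number from compound 2 to compound 3 (0.71 log units; beyond the scatter) shows. Compound 4 `CCCCCCCCC[C@H](CCn1cc(-c2ccccc2)nn1)n1cnc2c(Cl)ncnc21` brings a much larger change: 4-phenyl-1H-1,2,3-triazol-1-yl in place of hydroxy on a saturated chain carbon, three bonds along the chain from an aromatic nitrogen. Within the data shown here, none of the measured steps touches this place on the chain. The largest, a 9.2-fold lower number from compound 1 to compound 2 (0.96 log units; beyond the scatter), shows only that a small edit elsewhere moved the number modestly. No direction can be drawn from these data, so no step beyond the scatter is firmly expected, and the uncertainty is wide. The estimated step is a 1.1-fold lower number from compound 3 to compound 4 (0.04 log units; within the scatter). For compound 4 the expected value is 1500 nM, with an estimated range of 300 nM to 8000 nM.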

Compound 4, half-maximal inhibitory concentration: 8570 nM
Estimate against measurement, compound 4: 5.7-fold (0.76 log units) below; the whole stated range lies below it.
By their numbers in this assay, from the lowest: compound 2; then compounds 3 and 1 (each within the scatter of the next); then compound 4.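

This place on the chain does respond to change: in this assay, 4-phenyl-1H-1,2,3-triazol-1-yl in place of hydroxy gives a 5.3-fold higher number from compound 3 to compound 4 (0.72 log units; beyond the scatter), which means weaker inhibition. Among these compounds, the earlier compounds differed only in chain length, so this is the first reading of any change at this place. Nothing measured here accounts for the loss.

Going by these compounds, the change removes the hydroxy and adds both aromatic rings at once, and the share of each stays open. An amine, a methoxy or a triazole without its phenyl at this place could separate them.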